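The source may hold more compounds than are shown below. What is called first, only, known or untested is meant among the compounds shown, and "the series" means these compounds.

Compound 1 `COc1ccc2c(/C=C/C(=O)c3cc(OC)c(OC)c(SC)c3)c[nH]c2c1` and compound 2 `COc1cc(C(=O)/C=C/c2c[nH]c3ccccc23)cc(SC)c1OC` differ in one place: hydrogen in place of methoxy on an aromatic carbon. In a functional assay on A549 cells (Homo sapiens) for antiproliferative activity, read by MTT assay, with a stated time of 48 h (a higher number here means a weaker inhibitor, a lower number a stronger inhibitor), compound 1 gives 115 nM, while compound 2 gives 152 nM, a step of a 1.3-fold higher number from compound 1 to compound 2 (0.12 log units; within the scatter). Compound 3 `COc1ccc2c(/C=C(\C)C(=O)c3cc(OC)c(OC)c([Se]C)c3)c[nH]c2c1` is built on another core; how that core differs from the core of compound 1 is not broken down here. In this assay compound 3 gives 8 nM, the lowest of the three numbers, with compound 1 and compound 2 both beyond the scatter above it. Compound 4 `COc1cc(C(=O)/C(C)=C/c2c[nH]c3ccccc23)cc([Se]C)c1OC` carries the same change as compound 2 does, at the same place: hydrogen in place of methoxy on an aromatic carbon. Because the earlier step of a 1.3-fold higher number from compound 1 to compound 2 (0.12 log units; within the scatter) lay within the scatter, compound 4 is expected to sit near compound 3, with an expected step of a 1.3-fold higher number from compound 3 to compound 4 (0.10 log units; within the scatter). In this assay compound 4 is estimated at 10 nM, expected between 5 nM and 22 nM.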

Compound 4, half-maximal inhibitory concentration: 12 nM
Compound 4: middle estimate off by 1.2-fold (0.08 log units), on the low side; low and high end bracket the measured number.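

On the second core, hydrogen in place of methoxy gives a 1.5-fold higher number from compound 3 to compound 4 (0.18 log units; within the scatter) in this assay. The change carries across the two cores with no difference that stands out from the scatter: the same change on two cores in this assay, a 1.3-fold higher number (0.12 log units; within the scatter) from compound 1 to compound 2 and a 1.5-fold higher number (0.18 log units; within the scatter) from compound 3 to compound 4, 1.1-fold (0.05 log units) apart, within the scatter of two such steps This shows only that, on these two cores, the exchange brings no step beyond the scatter in this assay; it does not show that the same would hold on a further core or in another assay.

The compounds shown leave open whether another group at this place, such as a hydroxy group, a fluorine or an amine, would behave as hydrogen does. Also open, on these data alone, is what each difference between the two cores contributes on its own.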